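The source may report more compounds than this note shows. Statements on the series, on what has been measured and on what is new or still open speak of the compounds shown alone.

Working notes on a small set of dihydrofuran carboxamides tested in a functional assay on QGY7701 cells (Homo sapiens) for cytotoxicity, read by MTT assay, with a stated time of 24 h; a higher number here means a weaker inhibitor, a lower number a stronger inhibitor.

Compound 1 `C=CC1=C(C(=O)NCc2ccc(C)cc2)C(c2ccc(F)cc2)OC1` carries a 4-methylbenzyl amide and a 4-fluorophenyl group on the shared core; in this assay compound 1 gives 62100 nM. Compound 2 `C=CC1=C(C(=O)NCc2ccccc2F)C(c2ccc(F)cc2)OC1` differs from compound 1 only in the amide substituent, (2-fluorophenyl in place of 4-methylphenyl on a saturated chain carbon bound to an amide-type nitrogen). In this assay compound 2 gives 51400 nM, so the step of a 1.2-fold lower number from compound 1 to compound 2 (0.08 log units; within the scatter) does not stand out from the usual spread of such measurements.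

Compound 3 `C=CC1=C(C(=O)NCc2ccc(C)cc2)C(c2ccc(OC)cc2)OC1` keeps the 4-methylbenzyl amide of compound 1 but differs in the core: methoxy in place of fluoro on an aromatic carbon. In this assay compound 3 gives 43100 nM, and the step of a 1.4-fold lower number from compound 1 to compound 3 (0.16 log units; within the scatter) is likewise inside the scatter. Among compounds 1, 2 and 3 no value separates from the others, so none can be called the stronger or weaker inhibitor here.

Compound 4 `C=CC1=C(C(=O)NCc2ccccc2F)C(c2ccc(OC)cc2)OC1` is not yet measured. It relates to compound 3 exactly as compound 2 relates to compound 1: 2-fluorophenyl in place of 4-methylphenyl on a saturated chain carbon bound to an amide-type nitrogen, and the place is the same in both pairs, so this is the same change carried onto the methoxy-bearing core. For the measured compounds named here, with only one prior instance of the change, and that instance within the scatter, the expected step is small and rests on compound 1 and compound 2 alone, so for compound 4 the estimate is a 1.2-fold lower number from compound 3 to compound 4 (0.08 log units; within the scatter). On that basis compound 4 is expected to give 36000 nM in this assay, with a likely range from 18000 nM to 72000 nM.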

Compound 4, half-maximal inhibitory concentration: > 100000 nM
Compound 4 ended at the assay's limit; the forecaster's own chance of this, stated with the estimate: 5%; middle value at least 2.7-fold (0.44 log units) from the limit.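

In this assay compound 4 gives > 100000 nM, which is a limit of the assay and not a number. Carried onto the methoxy-bearing core, 2-fluorobenzyl in place of 4-methylbenzyl gives an at least 2.3-fold higher number from compound 3 to compound 4 (0.36 log units; beyond the scatter), so this change does not transfer as a constant step from one core to the other: the same change on two cores in this assay, a 1.2-fold lower number (0.08 log units; within the scatter) from compound 1 to compound 2 and an at least 2.3-fold higher number (0.36 log units; beyond the scatter) from compound 3 to compound 4, at least 2.8-fold (0.44 log units) apart, beyond the scatter of two such steps

Read the other way, methoxy in place of fluoro gives an at least 1.9-fold higher number from compound 2 to compound 4 (0.28 log units; that floor lies within the scatter), and this change also depends on its partner group, but the size of the gap remains unread past a floor, and one pair of cores shows neither the reason for the gap nor how the change behaves on any further core: the same change on two cores in this assay, a 1.4-fold lower number (0.16 log units; within the scatter) from compound 1 to compound 3 and an at least 1.9-fold higher number (0.28 log units; that floor lies within the scatter) from compound 2 to compound 4, at least 2.8-fold (0.44 log units) apart, beyond the scatter of two such steps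

The compounds shown leave open whether the departure is tied to the 2-fluorobenzyl amide together with methoxy, or would also appear with another amide substituent, such as an unsubstituted benzyl, a chlorobenzyl or a longer chain on the amide nitrogen. Also open, on these data alone, is how a hydroxy group or an amine in the place of methoxy would behave with each of the two amides.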